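From Compound 3 to Compound 4: Bromo to Trifluoromethyl

The source may hold more compounds than are shown below. What is called first, only, known or untested is meant among the compounds shown, and "the series" means these compounds.

Of the compounds shown here, three sharing one core have been tested in a functional assay on L1210 cells (Mus musculus) for antiproliferative activity; on this read-out lower numbers stand for stronger inhibition and higher numbers for weaker inhibition. Compound 1, `O=c1[nH]c(=O)n([C@H]2C[C@H](O)[C@@H](COP(=O)(O)O)O2)cc1Br`, gives 457 ug/mL in this assay. Compound 2, `COP1(=O)OC[C@H]2O[C@@H](n3cc(Br)c(=O)[nH]c3=O)C[C@@H]2O1`, reaches only a limit of this assay, > 100 ug/mL. Compound 3, `O=c1[nH]c(=O)n([C@H]2C[C@@H]3O[PH](O)(O)OC[C@H]3O2)cc1Br`, also gives only a limit of this assay, > 1000 ug/mL. Compound 3 therefore stands at the limit of > 1000 ug/mL in this assay, at which 1 of the 3 values shown sits. Compound 2 stands at the limit of > 100 ug/mL in this assay, at which 1 of the 3 values shown sits. Among the three, only compound 1 has an actual number, and no measured pair of compounds differing in a single place is available to show how large a change of one group can be.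

Compound 4, `O=c1[nH]c(=O)n([C@H]2C[C@@H]3O[PH](O)(O)OC[C@H]3O2)cc1C(F)(F)F`, differs from compound 3 in one place: trifluoromethyl in place of bromo on an aromatic carbon. Among the compounds with values here, with no measured step to lean on, the size of this change can only be estimated. Compound 4 is expected to stay close to compound 3, with an estimated step of a number no higher from compound 3 to compound 4 (the limit leaves the size open) in this assay, which is not expected to go beyond the usual scatter, and it is expected that this assay again reports only a limit rather than a number. The estimate for compound 4 in this assay is 1000 ug/mL, expected to fall between 200 ug/mL and 3000 ug/mL.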

Compound 4, concentration for 50% inhibition: 22 ug/mL
Compound 4: the middle estimate sits 45-fold (1.66 log units) above what was measured; the whole stated range lies above it.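

Within the data shown here, until this point, no comparison of two compounds differing in one place was available in this assay, so nothing showed how much a single group could matter. Putting trifluoromethyl in place of bromo on this aromatic carbon brings an at least 45-fold lower number from compound 3 to compound 4 (1.65 log units; beyond the scatter), which shows that the read-out is highly sensitive to the group at this position of the shared core. The exact size of the step cannot be read, because compound 3 gives only a limit and so the step is only a bound: the limit of > 1000 ug/mL in this assay, at which 1 of the 4 values shown sits.

With just bromo and trifluoromethyl compared here, the compounds shown do not tell whether the gain is particular to trifluoromethyl or would also appear with another group at this position, such as a chlorine atom, a methyl group, a nitrile or a longer chain. They also leave open whether the same exchange would have a similar effect on the core of compound 1 or of compound 2, which differ from compound 3 elsewhere in the molecule.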